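Tert-Butyl Replaces Chloro on the Aryl Ether

The source may report more compounds than this note shows. Statements on the series, on what has been measured and on what is new or still open speak of the compounds shown alone.

Compound 1 `NC1=NC2(CCSCC2)N(OCCCOc2cccc(Cl)c2)C(N)=N1`: 260 nM
Compound 2 `NC1=NC2(CCOCC2)N(OCCCOc2cccc(Cl)c2)C(N)=N1`: 520 nM
Compound 3 `NC1=NC2(CCSCC2)N(OCCCOc2ccc(Cl)cc2)C(N)=N1`: 430 nM

In a functional assay on HL-60 cells (Homo sapiens) for antiproliferative activity, read by MTT assay, with a stated time of 72 h (a higher number here means a weaker inhibitor, a lower number a stronger inhibitor), compound 3 gives 430 nM, which sits within the scatter of both compound 1 and compound 2. Compound 4 `CC(C)(C)c1ccc(OCCCON2C(N)=NC(N)=NC23CCSCC3)cc1` differs from compound 3 by tert-butyl in place of chloro on an aromatic carbon. Going by the values given here, the only single change measured so far is a 1.7-fold higher number from compound 1 to compound 3 (0.22 log units; within the scatter), which moves the chloro rather than exchanging it, so no measured step speaks directly to this swap. With nothing comparable in hand, the step from compound 3 to compound 4 in this assay is expected to stay small, around a 1.2-fold higher number from compound 3 to compound 4 (0.07 log units; within the scatter), with the estimate carrying wide uncertainty. Compound 4 is therefore expected to give about 500 nM, between 200 nM and 1500 nM.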

Compound 4, half-maximal inhibitory concentration: 280 nM
For compound 4 the middle estimate is 1.8-fold (0.25 log units) above the measured one; the measured number falls inside the stated range.
By their numbers in this assay, from the lowest: compounds 1, 4, 3 and 2 (each within the scatter of the next).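

In this assay, tert-butyl in place of chloro on this aromatic carbon gives a 1.5-fold lower number from compound 3 to compound 4 (0.19 log units; within the scatter) and that step lies within the scatter. The position, para to a large group, therefore accepts 4 heavy atoms where chloro has 1, with no change that can be told apart from repeat-measurement noise. No measured evidence bears on this result. Chloro and tert-butyl each have 0 hydrogen-bond donors and 0 hydrogen-bond acceptors. On these data alone, how an amine or a carboxylic acid on this same aromatic carbon would behave remains open.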